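The source may hold more compounds than are shown below. What is called first, only, known or untested is meant among the compounds shown, and "the series" means these compounds.

Measured compounds:
compound 1 `NS(=O)(=O)Oc1ccc2c(c1)CN(C(=O)c1cccc(N3CCN(c4ncccn4)CC3)c1)CC2` — 1.6%
compound 2 `CC(C)CCN(CCC(C)C)c1ccc(C(=O)N2CCc3ccc(OS(N)(=O)=O)cc3C2)cc1` — 47%
compound 3 `NS(=O)(=O)Oc1ccc2c(c1)CN(C(=O)c1cccc(N3CCCCC3)c1)CC2` — 1%

In an assay on HEK293 cells for inhibition of Steryl-sulfatase (Homo sapiens), tested at 0.1 uM (a lower number here means a weaker effect, a higher number a stronger effect of the compound at the concentration tested), compound 2 gives 47%, the highest of the three numbers; compound 1 and compound 3 both sit far lower, well beyond the scatter. Compound 4 `CCCN(CCC)c1ccc(C(=O)N2CCc3ccc(OS(N)(=O)=O)cc3C2)cc1` has not been measured in this assay. Compound 4 differs from compound 2 in one place: dipropylamino in place of diisopentylamino on an aromatic carbon. Among the measured compounds shown here, no measured pair shows the effect of shortening this chain, so the expectation rests on compound 2 alone. The step from compound 2 to compound 4 in this assay is expected to be a decrease, a number 27 percentage points lower from compound 2 to compound 4 (beyond the scatter), beyond the scatter. Compound 4 is therefore estimated to give 20% in this assay, between 3% and 45%.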

Compound 4, a percentage reported as inhibition, at one concentration (the size of the read-out at that concentration, not a potency): 36.6%
Beside the measured number, compound 4's estimate is 16.6 percentage points below it; measured number inside the range.
By their numbers in this assay, from the lowest: compounds 3 and 1 (each within the scatter of the next); then compound 4; then compound 2.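

Swapping diisopentylamino for dipropylamino on an aromatic carbon para to a large group gives a number 10.4 percentage points lower from compound 2 to compound 4 (beyond the scatter) in this assay, the first measured step at this position. The effect does not depend entirely on the longer chain, since compound 4 still gives 36.6% at the concentration tested. No measurement at hand accounts for the size of this step. A single step sets no trend with chain length. From the compounds shown here alone, whether diethylamino, a ring amine such as pyrrolidine, or a chain ending in a carboxylic acid would lower the number further remains open.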